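Replacing the 2-hydroxyethyl group of compound 3

A few compounds are considered here, and "the series" means these few. Any claim that something is new, unique, unknown or untested is made for them only; others in the source may bear on it.

Measured in an ADME assay (Homo sapiens) for cytotoxicity; a lower number here means that less compound is tolerated, a higher number that more compound is tolerated:
Compound 1 `Nc1nn2c(O)cc(-c3ccccc3)nc2c1[N+](=O)[O-]`: > 100 ug/mL
Compound 2 `Nc1nn2c(O)cc(CNNc3ccc(F)cc3)nc2c1[N+](=O)[O-]`: > 100 ug/mL
Compound 3 `Nc1nn2c(O)cc(CNCCO)nc2c1[N+](=O)[O-]`: > 50 ug/mL

In this assay compound 3 stands at > 50 ug/mL, which is a limit and not a number. Compound 1 and compound 2 are also known only by limits, so none of the three has a measured midpoint.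

Compound 4 `CCSC(N)NCc1cc(O)n2nc(N)c([N+](=O)[O-])c2n1` carries amino(ethylsulfanyl)methyl in place of 2-hydroxyethyl on an amine nitrogen. The closest measured change is a step that the two limits leave unreadable from compound 2 to compound 3, made on the same amine nitrogen. The other is a step that the two limits leave unreadable from compound 1 to compound 3. Among the measured compounds shown here, neither has a readable size, so no measured step can be carried over, and no direction can be assigned with confidence.

The change expected in this assay is therefore only a loose estimate, a step that the limit leaves unreadable from compound 3 to compound 4. All three neighbours reach only limits, so a further limit is quite likely. For compound 4 the estimated value is 80 ug/mL, with an expected range of 25 ug/mL to 200 ug/mL.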

Compound 4, half-maximal cytotoxic concentration: > 50 ug/mL
Compound 4: only a limit was reported; the forecaster's own chance of this, stated with the estimate: 65%; the middle value is on the limit's open side.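

In this assay compound 4 gives > 50 ug/mL, which is a limit. None of its steps from compound 1, compound 2 or compound 3 can be read. The compounds shown leave open where any of the four actually becomes cytotoxic, and whether these changes alter that concentration.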